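This account rests on a few compounds, and the source may have more. Where it says the series, first, only, none or still open, it means among the compounds named here.

Compound 1 `O=C(CN1CCN(c2ccc(F)cc2)CC1)Nc1nc2c(s1)CCCC2`: 77 nM
Compound 2 `O=C(CN1CCN(c2ccncc2)CC1)Nc1nc2c(s1)CCCC2`: > 1000 nM
Compound 3 `O=C(CN1CCN(c2ccc(F)cc2)CC1)Nc1nc2c(s1)CCCCC2`: 120 nM

In an assay on isolated protein for inhibition of long-chain fatty acid transport protein 1 (Homo sapiens), read by scintillation counting, with a stated time of 20 min (on this read-out lower numbers stand for stronger inhibition and higher numbers for weaker inhibition), compound 1 gives 77 nM and compound 3 gives 120 nM. Compound 2 is reported only as a limit of the assay, > 1000 nM, which places it at the limit of > 1000 nM in this assay, at which 1 of the 3 values shown sits. Among the measured compounds shown here, one measured step bears on the question at hand, the change from compound 1 to compound 2, and it was large: an at least 12-fold higher number from compound 1 to compound 2 (1.11 log units; beyond the scatter).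

Compound 4 `O=C(CN1CCN(c2cccc(F)c2)CC1)Nc1nc2c(s1)CCCC2` has not yet been measured. It differs from compound 2 in one place: 3-fluorophenyl in place of pyridin-4-yl on an amine nitrogen in a ring. This reverses the kind of change that carried compound 1 to the limit, although the group entering here is 3-fluorophenyl rather than the 4-fluorophenyl of compound 1. Because the step of an at least 12-fold higher number from compound 1 to compound 2 (1.11 log units; beyond the scatter) went in the weaker direction, its reversal is expected to give a large drop in the number, into the region where compound 1 and compound 3 sit. The expected step is an at least 8.3-fold lower number from compound 2 to compound 4 (0.92 log units; beyond the scatter). Compound 4 is therefore estimated at 120 nM, with a range from 40 nM to 400 nM.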

Compound 4, half-maximal inhibitory concentration: > 1000 nM
Compound 4 was reported as a limit; the forecaster's own chance of this, stated with the estimate: 5%; middle value at least 8.3-fold (0.92 log units) from the limit.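

Replacing 4-fluorophenyl with 3-fluorophenyl on the amine nitrogen in the ring gives an at least 12-fold higher number from compound 1 to compound 4 (1.11 log units; beyond the scatter) in this assay, so a fluorophenyl group at this place does not by itself keep the number low. The earlier compounds shown here set 4-fluorophenyl only against pyridin-4-yl, but this loss comes with a six-membered aromatic ring of carbon only, so the ring nitrogen of pyridin-4-yl cannot be the whole account of the weak result for compound 2. Compound 2 and compound 4 are both limits of the assay, so the step between them cannot be read, and they stand together: the limit of > 1000 nM in this assay, at which 2 of the 4 values shown sit.

Going by these compounds, how far either compound lies past that limit stays open. So does whether unsubstituted phenyl or 4-chlorophenyl at this place would keep the number near that of compound 1, at 77 nM.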